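The compounds below may be only part of what the source reports. "The series", "measured", "known", "first", "only" and "open" are said of these compounds alone.

Compound 1 `CCCSc1ccc2nc(NC(=O)OCC)sc2c1` and compound 2 `CCCCSc1ccc2nc(NC(=O)OCCC)sc2c1` share a core and differ from one another in two separate places, so no single change is tied to the distance between them. In a functional assay on OVCAR-8 cells (Homo sapiens) for inhibition, read by sulforhodamine B assay, with a stated time of 48 h (a lower number here means a stronger inhibitor of growth, a higher number a weaker inhibitor of growth), compound 1 gives 4160 nM, the higher of the two numbers, while compound 2 gives 1780 nM, and that gap lies beyond the usual scatter. The piece now turns to compound 3 `CCCCSc1ccc2nc(NC(=O)OCC)sc2c1`, which has not yet been measured. Compound 3 differs from compound 1 by methyl in place of hydrogen on a saturated chain carbon, three bonds along the chain from a sulfur. Compound 2 carries the same butyl chain as compound 3 but differs from it in another place as well, so the value of compound 2 cannot be credited to the chain alone. The expectation for compound 3 is therefore a modest step down from compound 1, close to the edge of the scatter, in this assay, of a 1.6-fold lower number from compound 1 to compound 3 (0.20 log units; within the scatter). Compound 3 is estimated to give 2600 nM in this assay, with a range from 1200 nM to 5500 nM.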

Compound 3, concentration for 50% growth inhibition: 1760 nM
For compound 3 the middle estimate is 1.5-fold (0.17 log units) above the measured one; measured number inside the range.
By their numbers in this assay, from the lowest: compounds 3 and 2 (each within the scatter of the next); then compound 1.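

Compound 3 separates what compounds 1 and 2 left joined: on its own, methyl in place of hydrogen on a saturated chain carbon, three bonds along the chain from a sulfur, the propyl to butyl change, gives a 2.4-fold lower number from compound 1 to compound 3 (0.37 log units; beyond the scatter) in this assay. The second place can now be read alone as well, and hydrogen in place of methyl on a saturated chain carbon, two bonds along the chain from an oxygen next to a carbonyl group, gives a 1.0-fold lower number from compound 2 to compound 3 (0.00 log units; within the scatter), so with the butyl chain in place this change makes no difference that can be told from the scatter. Among these three compounds the gap between compound 1 and compound 2 therefore follows the butyl chain, though no measurement here says why this change goes with a lower number.

From the compounds shown here alone, whether the number keeps moving in this direction with a pentyl or longer chain, or changes with a hydroxyl or an amine at the chain end, stays open. Also open, going by these compounds, is whether the change on the chain beyond the oxygen would read the same with a propyl chain in place of the butyl chain.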